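This account rests on a few compounds, and the source may have more. Where it says the series, first, only, none or still open, it means among the compounds named here.

Measured in a functional assay on SMMC-7721 cells (Homo sapiens) for cytotoxicity, read by MTT assay, with a stated time of 24 h; a higher number here means a weaker inhibitor, a lower number a stronger inhibitor:

compound 1, `O=C1/C(=C/c2cccc([N+](=O)[O-])c2)CN(S(=O)(=O)c2ccc(F)cc2)C/C1=C\c1ccccc1F`, gives 7820 nM
compound 2, `N#Cc1ccc(/C=C2\CN(S(=O)(=O)c3ccc(F)cc3)C/C(=C\c3ccccc3F)C2=O)cc1`, gives 10300 nM
compound 3, `COc1cc(/C=C2\CN(S(=O)(=O)c3ccc(NC(C)=O)cc3)C/C(=C\c3cccc([N+](=O)[O-])c3)C2=O)cc(OC)c1OC`, gives 1950 nM

Compound 2 differs from compound 1 in one place, namely (4-cyanophenyl in place of 3-nitrophenyl on a double-bonded chain carbon bound to a double-bonded ring carbon). This change gave a 1.3-fold higher number from compound 1 to compound 2 (0.12 log units; within the scatter), so the two numbers sit within the scatter of each other and no order can be read between them. Compound 3 gives the lowest number of the three in this assay, with its nearest neighbour being compound 1 and its furthest compound 2, both beyond the scatter. The difference between the core of compound 3 and the core of compound 1 is not broken down here.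

Compound 4, `COc1cc(/C=C2\CN(S(=O)(=O)c3ccc(NC(C)=O)cc3)C/C(=C\c3ccc(C#N)cc3)C2=O)cc(OC)c1OC`, is not yet measured. It differs from compound 3 by 4-cyanophenyl in place of 3-nitrophenyl on a double-bonded chain carbon bound to a double-bonded ring carbon, the same change already seen from compound 1 to compound 2. The step of a 1.3-fold higher number from compound 3 to compound 4 (0.11 log units; within the scatter) is expected in this assay, resting on the near-flat result of a 1.3-fold higher number from compound 1 to compound 2 (0.12 log units; within the scatter), since the same change on a different core gave no movement beyond the scatter. The estimate for compound 4 in this assay is therefore 2500 nM, with a likely range from 1000 nM to 6500 nM.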

Compound 4, half-maximal inhibitory concentration: 1730 nM
Beside the measured number, compound 4's estimate is 1.4-fold (0.16 log units) above it; low and high end bracket the measured number.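

In this assay, putting 4-cyanophenyl in place of 3-nitrophenyl gave a 1.1-fold lower number from compound 3 to compound 4 (0.05 log units; within the scatter), so on this second core the change again produced no movement beyond the scatter. The two steps also agree with each other: the same change on two cores in this assay, a 1.3-fold higher number (0.12 log units; within the scatter) from compound 1 to compound 2 and a 1.1-fold lower number (0.05 log units; within the scatter) from compound 3 to compound 4, 1.5-fold (0.17 log units) apart, within the scatter of two such steps. Going by these compounds alone, this shows that the near-flat result carried over between these two cores in this one cell assay, but with only two pairs it does not show that the same would hold on any other core or in any other assay, and it does not explain why the change has so little effect.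

The compounds shown leave open whether a different kind of group in this place, such as an amine or a carboxylic acid on the phenyl ring, would give a step beyond the scatter. They also leave open which of the differences between the core of compound 1 and the core of compound 3 matters in this assay, as no pair shown isolates any one of them.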